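The source may report more compounds than this note shows. Statements on the series, on what has been measured and on what is new or still open speak of the compounds shown alone.

Compound 1 `O=C1/C(=C/c2cccnc2)CN(S(=O)(=O)c2ccccc2)C/C1=C\c1ccccc1F` carries a phenylsulfonyl group and a pyridin-3-yl arm. In a functional assay on SMMC-7721 cells (Homo sapiens) for cytotoxicity, read by MTT assay, with a stated time of 24 h (a higher number here means a weaker inhibitor, a lower number a stronger inhibitor), compound 1 gives 19100 nM. Compound 2 `Cc1ccc(S(=O)(=O)N2C/C(=C\c3cccnc3)C(=O)/C(=C/c3ccccc3F)C2)cc1` differs from it only by methyl in place of hydrogen on an aromatic carbon; in this assay compound 2 gives 10300 nM, the step being a 1.9-fold lower number from compound 1 to compound 2 (0.27 log units; within the scatter). Compound 3 `O=C1/C(=C/c2ccncc2)CN(S(=O)(=O)c2ccccc2)C/C1=C\c1ccccc1F` has a different core, the difference between the two cores being (pyridin-4-yl in place of pyridin-3-yl on a double-bonded chain carbon bound to a double-bonded ring carbon); in this assay compound 3 gives 17500 nM, the step being a 1.1-fold lower number from compound 1 to compound 3 (0.04 log units; within the scatter). Compound 4 `Cc1ccc(S(=O)(=O)N2C/C(=C\c3ccncc3)C(=O)/C(=C/c3ccccc3F)C2)cc1`, not yet measured, differs from compound 3 by methyl in place of hydrogen on an aromatic carbon, the same change as that from compound 1 to compound 2, at the same place on the phenylsulfonyl group. The expected step from compound 3 to compound 4 is a 1.8-fold lower number from compound 3 to compound 4 (0.27 log units; within the scatter), set beside the measured 1.9-fold lower number from compound 1 to compound 2 (0.27 log units; within the scatter), and rests on that single earlier step alone. Compound 4 is thus expected to give 9500 nM in this assay, with a likely range from 5000 nM to 18000 nM.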

Compound 4, half-maximal inhibitory concentration: 13200 nM
Beside the measured number, compound 4's estimate is 1.4-fold (0.14 log units) below it; the range from low to high includes it.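

In this assay, methyl in place of hydrogen on the phenylsulfonyl group gives a 1.3-fold lower number from compound 3 to compound 4 (0.12 log units; within the scatter), and this step agrees with the earlier one within the scatter: the same change on two cores in this assay, a 1.9-fold lower number (0.27 log units; within the scatter) from compound 1 to compound 2 and a 1.3-fold lower number (0.12 log units; within the scatter) from compound 3 to compound 4, 1.4-fold (0.15 log units) apart, within the scatter of two such steps

Pyridin-4-yl in place of pyridin-3-yl gives a 1.3-fold higher number from compound 2 to compound 4 (0.11 log units; within the scatter), and the two steps for this change also agree within the scatter: the same change on two cores in this assay, a 1.1-fold lower number (0.04 log units; within the scatter) from compound 1 to compound 3 and a 1.3-fold higher number (0.11 log units; within the scatter) from compound 2 to compound 4, 1.4-fold (0.15 log units) apart, within the scatter of two such steps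

Each change therefore carries between these cores without a difference that can be resolved, but every step is itself within the scatter, so neither change is shown to alter the read-out, and the agreement rests on one pair of cores per change.

Still open, going by these compounds, is whether an amine or a carboxylic acid in place of the methyl would give a step beyond the scatter. Also open, on these data alone, is whether a pyridin-2-yl arm would follow the same pattern.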